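The source may report more compounds than this note shows. Statements on the series, on what has been measured and on what is new or still open speak of the compounds shown alone.

Measured so far:
compound 1 `Cc1ccc(CN2CCC(CCN(Cc3ccc(-c4ccc(F)cc4)cc3)C(=O)NC(C)C)CC2)cc1`: 383 nM
compound 2 `CC(=O)OCC(C)(C)NC(=O)N(CCC1CCN(Cc2ccc(C)cc2)CC1)Cc1ccc(-c2ccc(F)cc2)cc1`: 409 nM

Among the compounds with values here, in an in vitro functional assay on HEK293 cells for antagonist activity at melanin-concentrating hormone receptor 1 (Homo sapiens), read by GTPgammaS binding, with a stated time of 45 min (a lower number here means a stronger inhibitor, a higher number a weaker inhibitor), compound 2 gives 409 nM, the higher of the two numbers, with compound 1 giving 383 nM as the nearest value; the only measured step, a 1.1-fold higher number from compound 1 to compound 2 (0.03 log units; within the scatter), is within the scatter. Compound 3 `Cc1ccc(CN2CCC(CCN(Cc3ccc(-c4ccc(F)cc4)cc3)C(=O)NC(C)(C)CO)CC2)cc1` differs from compound 2 by hydrogen in place of acetyl on an oxygen on a saturated carbon. Within the data shown here, no measured pair covers this change; the measured step at the same branch was flat, so no step beyond the scatter is expected for compound 3, estimated as a 1.2-fold lower number from compound 2 to compound 3 (0.07 log units; within the scatter). Compound 3 is expected at 350 nM, range 150 nM to 900 nM.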

Compound 3, antagonist equilibrium constant: 41.4 nM
Compound 3: the middle estimate sits 8.5-fold (0.93 log units) above what was measured; the whole stated range lies above it.
By their numbers in this assay, from the lowest: compound 3; then compounds 1 and 2 (each within the scatter of the next).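

In this assay, the gain at this position depends on the free hydroxyl: removing the acetyl from the oxygen gives a step beyond the scatter (a 9.9-fold lower number from compound 2 to compound 3 (0.99 log units; beyond the scatter)). Hydroxymethyl also separates from hydrogen on the same saturated chain carbon (a 9.3-fold lower number from compound 1 to compound 3 (0.97 log units; beyond the scatter)), whereas acetoxymethyl did not (a 1.1-fold higher number from compound 1 to compound 2 (0.03 log units; within the scatter)). No evidence on the origin of this step is available.

Open, from the compounds shown here alone, is whether an amine, a carboxylic acid or a longer hydroxyalkyl chain at this carbon would match compound 3 (41.4 nM).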